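The source may hold more compounds than are shown below. What is called first, only, known or untested is meant among the compounds shown, and "the series" means these compounds.

Measured compounds:
- compound 1, `NC(=O)CC[C@H](NC(=O)c1cc2ccccc2cn1)C(=O)OCc1ccccc1`: 11.9%
- compound 2, `O=C(CNC(=O)c1cc2ccccc2cn1)OCc1ccccc1`: 16.1%

Both compounds were tested in a functional assay on the whole organism (CCRF S-180 cells, Mus musculus) for inhibition, in a xenograft, with stated times of 7 days and 24 h, at a dose of 100 umol/kg by the intraperitoneal route; on this read-out higher numbers stand for more inhibition at the one dose given (going by the name of the read-out) and lower numbers for less inhibition. Compound 2 gives the higher of the two numbers, but its distance to compound 1, a number 4.2 percentage points higher from compound 1 to compound 2 (within the scatter), lies within the scatter, so the two cannot be told apart. Compound 3, `O=C(C[C@H](NC(=O)c1cc2ccccc2cn1)C(=O)OCc1ccccc1)OCc1ccccc1`, has not yet been measured. It differs from compound 2 by (benzyloxycarbonyl)methyl in place of hydrogen on a saturated chain carbon bound to an amide-type nitrogen and a carbonyl carbon. Going by the values given here, the one measured step that speaks to this kind of change is the one from compound 1 to compound 2, where a side chain on that same carbon was replaced by hydrogen and the read-out moved by a number 4.2 percentage points higher from compound 1 to compound 2 (within the scatter), which is within the scatter. A side chain entering at that carbon is therefore not expected to move the number beyond the scatter either, in either direction, although the group entering here is not the one that left before. The estimate for compound 3 in this assay is 14%, with a range from 3% to 26%, which means an expected step of a number 2.1 percentage points lower from compound 2 to compound 3 (within the scatter).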

Compound 3, a percentage reported as inhibition, in the whole organism at one dose (the size of the read-out at that dose, not a potency): 37.5%
Compound 3: the middle estimate sits 23.5 percentage points below what was measured, outside the stated range (above it).
By their numbers in this assay, from the lowest: compounds 1 and 2 (each within the scatter of the next); then compound 3.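

In this assay the saturated chain carbon bound to an amide-type nitrogen and a carbonyl carbon turns out not to be indifferent to what it carries: with (benzyloxycarbonyl)methyl in place of hydrogen there is a number 21.4 percentage points higher from compound 2 to compound 3 (beyond the scatter), whereas the earlier exchange of 2-carbamoylethyl for hydrogen stayed within the scatter. The comparison of the two side chains agrees, since a number 25.6 percentage points higher from compound 1 to compound 3 (beyond the scatter) goes with benzyloxycarbonyl in place of carbamoylmethyl on a saturated chain carbon, two bonds along the chain from an amide-type nitrogen and a carbonyl carbon, so among these three compounds it is the kind of side chain that counts, not the mere presence of one. The data shown offer no measurement that could explain this rise.

Still open, on these data alone, is which part of the entering group goes with the higher number, the six-membered aromatic ring or the ester alone; a side chain ending in a carboxylic acid or a methyl ester would separate the two. As far as these compounds go, each number also describes a single dose, so how the compounds would compare at other doses remains unknown.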